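Cytotoxicity of a fluorinated analogue bearing isopropoxy

This account rests on a few compounds, and the source may have more. Where it says the series, first, only, none or still open, it means among the compounds named here.

The study surveys a small set of carbinols in an ADME assay on L6 cells (Rattus norvegicus) for cytotoxicity, read by resazurin assay, with a stated time of 72 h; on this read-out higher numbers stand for weaker inhibition and lower numbers for stronger inhibition. Compound 1 `CC(C)Oc1cccc(C(O)(c2ccc(Cl)cc2)c2cccnc2)c1` gives 67600 nM. Compound 2 `OC(c1ccc(Cl)cc1)(c1cccnc1)c1cccc(Br)c1` gives 54100 nM, and the step of a 1.2-fold higher number from compound 2 to compound 1 (0.10 log units; within the scatter) follows the change (isopropoxy in place of bromo on an aromatic carbon). Compound 3 `OC(c1ccc(Cl)cc1)(c1cccnc1)c1ccc(Br)cc1F` gives 79200 nM; its number and those of compound 1 and compound 2 all lie within the scatter of one another, so no order among them is claimed. The difference between the core of compound 3 and the core of compound 2 is not broken down here.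

Compound 4 `CC(C)Oc1ccc(C(O)(c2ccc(Cl)cc2)c2cccnc2)c(F)c1` has not yet been measured. It arises from compound 3 through (isopropoxy in place of bromo on an aromatic carbon). This is the same kind of change as that from compound 2 to compound 1, but the surroundings differ: in compound 1 the isopropoxy sits meta to a large group, whereas in compound 4 it sits meta to a fluoro group and para to a large group. Among the compounds with values here, because the only earlier example of this kind of change gave a 1.2-fold higher number from compound 2 to compound 1 (0.10 log units; within the scatter), the step is expected to be small, about a 1.1-fold higher number from compound 3 to compound 4 (0.03 log units; within the scatter) in this assay. Compound 4 is therefore estimated to give 85000 nM, with a range from 45000 nM to 160000 nM.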

Compound 4, half-maximal inhibitory concentration: 58200 nM
For compound 4 the middle estimate is 1.5-fold (0.16 log units) above the measured one; measured number inside the range.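

On the fluorinated core, isopropoxy in place of bromo gives a 1.4-fold lower number from compound 3 to compound 4 (0.13 log units; within the scatter) in this assay. Set beside the earlier example, the change carries from one core to the other with no difference that exceeds the scatter: the same change on two cores in this assay, a 1.2-fold higher number (0.10 log units; within the scatter) from compound 2 to compound 1 and a 1.4-fold lower number (0.13 log units; within the scatter) from compound 3 to compound 4, 1.7-fold (0.23 log units) apart, within the scatter of two such steps. Within the data shown here, this does not show that the change is without effect in general, since only two pairs are available and each step lies within the scatter, so the fact that one step shows a higher number and the other a lower number carries no weight.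

The compounds shown leave open whether a different replacement for bromo, such as an amine, a carboxylic acid or a longer chain, would give a step beyond the scatter on either core. They also leave open whether isopropoxy in place of bromo would behave in the same way on a core that carries a nitrile instead of the fluoro group.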